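A few compounds are considered here, and "the series" means these few. Any claim that something is new, unique, unknown or untested is made for them only; others in the source may bear on it.

Measured so far, in an assay on microsomes from liver for inhibition of sterol O-acyltransferase 1 (Rattus norvegicus); a higher number here means a weaker inhibitor, a lower number a stronger inhibitor: compound 1 `CCCCCC(=O)Nc1cc(-c2ccccc2)c(-c2ccccc2)nn1` gives only a limit, > 300000 nM. Compound 2 `CCCCCCSc1cc(-c2ccccc2)c(-c2ccccc2)nn1` gives 62000 nM. Compound 3 `CCCCCCC[S+]([O-])c1cc(-c2ccccc2)c(-c2ccccc2)nn1` gives 77000 nM.

Compound 3 thus holds the higher of the two numbers, but the gap between them is only a 1.2-fold higher number from compound 2 to compound 3 (0.09 log units; within the scatter). Compound 4 `CCCCCCCCC[S+]([O-])c1cc(-c2ccccc2)c(-c2ccccc2)nn1` carries the same core with ethyl in place of hydrogen on a saturated chain carbon, seven bonds along the chain from a sulfur. For the measured compounds named here, none of the measured steps lengthens the chain: an at least 4.8-fold lower number from compound 1 to compound 2 (0.68 log units; beyond the scatter) and an at least 3.8-fold lower number from compound 1 to compound 3 (0.59 log units; beyond the scatter) swap the whole group on the ring, and a 1.2-fold higher number from compound 2 to compound 3 (0.09 log units; within the scatter) adds oxygen to the sulfur. For a longer chain alone, a step in this assay no larger than the scatter is expected, a 1.4-fold lower number from compound 3 to compound 4 (0.15 log units; within the scatter). Compound 4 is therefore estimated at 55000 nM, between 15000 nM and 180000 nM.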

Compound 4, half-maximal inhibitory concentration: 87000 nM
The estimate for compound 4 lay 1.6-fold (0.20 log units) below the measured number; the range from low to high includes it.
By their numbers in this assay, from the lowest: compounds 2, 3 and 4 (each within the scatter of the next). At a limit, above all of these: compound 1.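

Lengthening the chain by ethyl in place of hydrogen, on a saturated chain carbon seven bonds along the chain from a sulfur, gives a 1.1-fold higher number from compound 3 to compound 4 (0.05 log units; within the scatter) in this assay. This is the first step shown that changes chain length alone, and at this position the change does not separate compound 4 from compound 3. No further measurement shown here bears on this result. From the compounds shown here alone, whether a much longer chain, or a chain carrying an amine or a carboxylic acid, would move the number beyond the scatter stays open.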